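Working notes: aryl group swapped for trifluoromethyl

The source may hold more compounds than are shown below. What is called first, only, known or untested is meant among the compounds shown, and "the series" means these compounds.

Three compounds of the series carry measurements in a functional assay on SNB-75 cells (Homo sapiens) for inhibition, read by sulforhodamine B assay, with a stated time of 48 h, tested at 10 uM; on this read-out higher numbers stand for more inhibition of growth at the one concentration tested and lower numbers for less inhibition of growth. Compound 1 `C/C(=N\O)c1ccc(NC(=O)Cn2nc(-c3ccc(Cl)cc3)nc2N)cc1` gives 12%, compound 2 `COc1cc(-c2nc(N)n(CC(=O)Nc3ccc(/C(C)=N\O)cc3)n2)cc(OC)c1OC` gives 25.9%, and compound 3 `CC(=O)c1ccc(NC(=O)Cn2nc(-c3ccc(Cl)cc3)nc2N)cc1` gives 6.47%. Compound 3 stands lowest of the three numbers; its nearest neighbour is compound 1, a step within the scatter, and the furthest is compound 2, whose number lies beyond the scatter above it. Going by the values given here, the single one-place step measured so far, a number 5.5 percentage points lower from compound 1 to compound 3 (within the scatter), concerns the group on the aromatic carbon of the amide-bearing ring and is within the scatter.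

Compound 4 `CC(=O)c1ccc(NC(=O)Cn2nc(C(F)(F)F)nc2N)cc1` differs from compound 3 at another place: trifluoromethyl in place of 4-chlorophenyl on an aromatic carbon. Among the compounds with values here, no measured step in this assay touches that position. Within the data shown here, compound 2 and compound 3 differ at two places at once, so their two values show only that a different aryl group together with the oxime gives a higher number. With nothing bearing on the change itself, no step beyond the scatter is expected in this assay, and the estimate rests on compound 3 alone. For compound 4 the expected step from compound 3 is a number 1.5 percentage points lower from compound 3 to compound 4 (within the scatter). Compound 4 is therefore estimated at 5%, within a range of -8% to 18%.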

Compound 4, percent growth inhibition at one concentration: 12.5%
Compound 4: middle estimate off by 7.5 percentage points, on the low side; the range from low to high includes it.
By their numbers in this assay, from the lowest: compounds 3, 1 and 4 (each within the scatter of the next); then compound 2.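

Going by these compounds alone, the step in this assay, a number 6 percentage points higher from compound 3 to compound 4 (within the scatter), is the first one-place reading at this aromatic carbon of the five-membered ring, and it stays within the scatter even though a group with a six-membered aromatic ring gives way to a smaller group with no ring. On the core of compound 3, then, this one replacement of 4-chlorophenyl by trifluoromethyl does not take the number outside the usual spread of the read-out, so the aromatic ring is not required at this place for a number of this size. Nothing available bears on the reason for this result.

Going by these compounds, whether the same replacement reads the same way on the core of compound 1, which carries the oxime, remains open, as does the reading of trifluoromethyl against the aryl group of compound 2. Also open, on these data alone, is how an amine, a carboxylic acid or a longer alkyl chain would read at this carbon, and whether any group there gives a step beyond the scatter.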